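Swapping the Urea Aryl Group on a Shared Core

This account rests on a few compounds, and the source may have more. Where it says the series, first, only, none or still open, it means among the compounds named here.

Measured so far:
compound 1 `O=C(Nc1ccccc1Cl)N1CCN(c2nc(-c3ccc4ccccc4n3)no2)CC1`, 140 nM
compound 2 `N#Cc1ccccc1NC(=O)N1CCC(c2nc(-c3ccc4ccccc4n3)no2)CC1`, 190 nM
compound 3 `COc1ccccc1NC(=O)N1CCC(c2noc(-c3ccc4ccccc4n3)n2)CC1`, 2400 nM

In a functional assay on Shh Light II cells (Mus musculus) for inhibition, read by a luciferase reporter (a higher number here means a weaker inhibitor, a lower number a stronger inhibitor), compound 2 gives 190 nM, the second highest of the three numbers. Its nearest neighbour is compound 1 at 140 nM, a gap that lies within the scatter, so the two cannot be ordered. Compound 3, at 2400 nM, stands well beyond the scatter from compound 2 and is the weakest of the three.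

Compound 4 `O=C(Nc1cccc2cccnc12)N1CCC(c2nc(-c3ccc4ccccc4n3)no2)CC1` is not yet measured. It differs from compound 2 in one place: quinolin-8-yl in place of 2-cyanophenyl on an amide-type nitrogen. Going by the values given here, no step between measured compounds matches this change, so the expectation rests on the shared core and the neighbouring values of compound 1 and compound 2. A small step is expected from compound 2 to compound 4, a 1.3-fold lower number from compound 2 to compound 4 (0.10 log units; within the scatter), toward a lower number but not clearly beyond the scatter. Compound 4 is estimated at 150 nM, with a range from 50 nM to 500 nM.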

Compound 4, half-maximal inhibitory concentration: 1400 nM
Beside the measured number, compound 4's estimate is 9.3-fold (0.97 log units) below it; measured number outside the range, above it.
By their numbers in this assay, from the lowest: compounds 1 and 2 (each within the scatter of the next); then compounds 4 and 3 (each within the scatter of the next).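

Quinolin-8-yl in place of 2-cyanophenyl on an amide-type nitrogen gives a 7.4-fold higher number from compound 2 to compound 4 (0.87 log units; beyond the scatter) in this assay and so shows that this position does not treat these two aryl groups alike. Going by these compounds alone, this is the first comparison here in which only one place changes, so the shift can be tied to this swap, which compounds 1, 2 and 3 could not do because they differ from one another in more than one place. Nothing measured here bears on why the number rises.

Going by these compounds, whether the shift goes with the added ring of quinolin-8-yl or with the loss of the nitrile stays open, as this one step changes both. An unsubstituted phenyl or a naphthalen-1-yl on the same nitrogen would help separate these readings, and whether the step carries over to the core of compound 1 is also unsettled.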